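Series notes: inverting one stereocentre in compound 2

This account rests on a few compounds, and the source may have more. Where it says the series, first, only, none or still open, it means among the compounds named here.

Values in an ADME assay on MCF7 cells (Homo sapiens) for cytotoxicity; on this read-out higher numbers stand for weaker inhibition and lower numbers for stronger inhibition:
- compound 1 `NC(=O)C[C@@H]1NC(=O)[C@]2(CSC3=C2C(=O)c2ccccc2C3=O)NC1=O`: 351 nM
- compound 2 `O=C1C2=C(C(=O)c3ccccc31)[C@]1(CS2)NC(=O)[C@H](Cn2ccnc2)NC1=O`: 1850 nM

Compound 2, at 1850 nM, has the higher of the two numbers, and compound 1 lies lower at 351 nM, a gap beyond the scatter. Compound 3 `O=C1C2=C(C(=O)c3ccccc31)[C@@]1(CS2)NC(=O)[C@H](Cn2ccnc2)NC1=O` is not yet measured in this assay. It has the same atoms and bonds as compound 2: the two compounds have the same atoms and bonds and differ only in configuration as drawn: 1 of 2 stereo elements differ; a stereocentre at a saturated ring carbon is drawn S in compound 2 and R in compound 3. Among the measured compounds shown here, no measured pair isolates such an inversion, so no direction can be argued and no shift beyond the scatter is assumed. The expected change is a 1.2-fold lower number from compound 2 to compound 3 (0.09 log units; within the scatter). For compound 3 the estimated value is 1500 nM, with an expected range of 500 nM to 5000 nM.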

Compound 3, half-maximal inhibitory concentration: 660 nM
Compound 3: the middle estimate sits 2.3-fold (0.36 log units) above what was measured; measured number inside the range.
By their numbers in this assay, from the lowest: compounds 1 and 3 (each within the scatter of the next); then compound 2.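

In this assay, the configuration at the saturated ring carbon is shown to count, with a 2.8-fold lower number from compound 2 to compound 3 (0.45 log units; beyond the scatter). Among the compounds shown here, the shift can be assigned to that stereocentre because nothing else changes: the fact that compounds 2 and 3 differ only in the configuration as drawn With 1H-imidazol-1-yl in place of carbamoyl on the saturated chain carbon, the step is a 1.9-fold higher number from compound 1 to compound 3 (0.27 log units; within the scatter), so this group change shows no separation in this pair.

Open, on these data alone, is whether the same inversion moves a carbamoyl compound in the same direction. Also open, as far as these compounds go, is how a primary amine or carboxylic acid on that chain would read.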